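A few compounds are considered here, and "the series" means these few. Any claim that something is new, unique, unknown or untested is made for them only; others in the source may bear on it.

Compound 1 `CCC(=O)Nc1cc(C(=O)Nc2ccc(OC)cc2)ccc1OCCCCl` was tested in a toxicity assay on Huh-7.5 cells (Homo sapiens) for inhibition, read by MTT assay, with a stated time of 96 h (a higher number here means that more compound is tolerated, a lower number that less compound is tolerated), where compound 1 gives 158000 nM. Among the two compounds measured so far it stands highest; its only companion is compound 2 `CC(C)Oc1ccc(C(=O)Nc2ccc(CN3CCN(C)CC3)c(C(F)(F)F)c2)cc1[N+](=O)[O-]`, which in this assay gives 3500 nM, a value that lies below that of compound 1 by a margin well beyond the usual scatter. Among the measured compounds shown here, no pair of measured compounds differing in a single place is available, so the effect of changing one group at a time cannot be read from the numbers in hand.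

Compound 3 `CCOc1ccc(C(=O)Nc2ccc(OC)cc2)cc1NC(=O)CC`, not yet measured, differs from compound 1 in one spot: hydrogen in place of chloromethyl on a saturated chain carbon, two bonds along the chain from an oxygen on an aromatic ring. Read a bond further out, the change is 3-chloropropoxy to ethoxy. For the measured compounds named here, with no measured step of this kind, the expectation rests on compound 1 alone, whose tolerance in this assay already stands at 158000 nM. The step of a 1.2-fold higher number from compound 1 to compound 3 (0.08 log units; within the scatter) is expected to be small, leaning toward a higher number or none beyond the scatter. Compound 3 is therefore estimated at 190000 nM, with a likely range from 80000 nM to 450000 nM.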

Compound 3, half-maximal cytotoxic concentration: 73200 nM
Estimate against measurement, compound 3: 2.6-fold (0.41 log units) above, and the stated range ends above it.
By their numbers in this assay, from the lowest: compound 2; then compound 3; then compound 1.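

Among the compounds shown here, this is the first measured step at this position. In this assay the change from 3-chloropropoxy to ethoxy, with hydrogen taking the place of chloromethyl on a saturated chain carbon, two bonds along the chain from an oxygen on an aromatic ring, reads a 2.2-fold lower number from compound 1 to compound 3 (0.33 log units; beyond the scatter) and so lies beyond the scatter, though it is modest: with the rest of the structure unchanged, the end of this chain does register in the tolerance of these cells, and less compound is tolerated with the shorter ethoxy group. Nothing at hand offers an explanation for the direction of this step.

A single step removes the chlorine and shortens the chain together, so the compounds shown cannot say which of the two matters; a plain propoxy group would keep the length without the chlorine, while a 3-hydroxypropoxy or 3-aminopropoxy group would show whether another atom at the chain end behaves like the chlorine. Compound 2 differs from both other compounds in more than one place, and it leaves open whether a longer chain or a terminal amine at this position would move the number further.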